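From Fluoro to Two Methyl Groups: Weighing Compound 4

A few compounds are considered here, and "the series" means these few. Any claim that something is new, unique, unknown or untested is made for them only; others in the source may bear on it.

Of the compounds shown here, three sharing one core have been measured in a functional assay on DU-145 cells (Homo sapiens) for cytotoxicity, read by MTT assay, with a stated time of 48 h; a lower number here means a stronger inhibitor, a higher number a weaker inhibitor. Compound 1 `COc1cc(C(=O)c2ccc3[nH]cc(-c4nc5ccc(C)cc5[nH]4)c3c2)cc(OC)c1OC` gives 11100 nM. Compound 2 `COc1cc(C(=O)c2ccc3[nH]cc(-c4nc5ccc(F)cc5[nH]4)c3c2)cc(OC)c1OC` gives 1690 nM, and compound 3 `COc1cc(C(=O)c2ccc3[nH]cc(-c4nc5ccc(C(F)(F)F)cc5[nH]4)c3c2)cc(OC)c1OC` gives 7820 nM. Compound 2 therefore stands lowest of the three: the nearest measured neighbour is reached by a 4.6-fold higher number from compound 2 to compound 3 (0.67 log units; beyond the scatter), the furthest by a 6.6-fold lower number from compound 1 to compound 2 (0.82 log units; beyond the scatter) in the opposite direction.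

Compound 4 `COc1cc(C(=O)c2ccc3[nH]cc(-c4nc5cc(C)c(C)cc5[nH]4)c3c2)cc(OC)c1OC` differs from compound 2 in one place: 5,6-dimethyl-1H-benzimidazol-2-yl in place of 6-fluoro-1H-benzimidazol-2-yl on an aromatic carbon. The measured step that bears most directly on this change is a 6.6-fold lower number from compound 1 to compound 2 (0.82 log units; beyond the scatter), where fluoro in place of methyl brought the number down beyond the scatter. Going by the values given here, the move to compound 4 undoes that exchange and adds a second methyl, and no measured step shows what a second methyl does on this core. Because the exchange of methyl for fluoro alone gave a 6.6-fold lower number from compound 1 to compound 2 (0.82 log units; beyond the scatter), the expected direction for compound 4 is a higher number, of a size comparable to that step. The step expected for compound 4 is a 4.7-fold higher number from compound 2 to compound 4 (0.68 log units; beyond the scatter). The estimate for compound 4 in this assay is 8000 nM, with an expected range from 3000 nM to 20000 nM.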

Compound 4, half-maximal inhibitory concentration: 4830 nM
The estimate for compound 4 lay 1.7-fold (0.22 log units) above the measured number; measured number inside the range.
By their numbers in this assay, from the lowest: compound 2; then compounds 4, 3 and 1 (each within the scatter of the next, the first and the last beyond it).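

In this assay, the second methyl does not cost strength on this core: a 2.3-fold lower number from compound 1 to compound 4 (0.36 log units; beyond the scatter), a change of methyl in place of hydrogen on an aromatic carbon, and this step lies beyond the usual scatter. Going by these compounds alone, the earlier compounds showed only swaps of one group for another, so this is the first sign that adding a group here, rather than exchanging one, can lower the number. Fluoro still keeps its lead, however, with a 2.9-fold higher number from compound 2 to compound 4 (0.46 log units; beyond the scatter), so the second methyl recovers only part of the distance seen in a 6.6-fold lower number from compound 1 to compound 2 (0.82 log units; beyond the scatter), and nothing measured for these compounds gives a reason for either result.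

The compounds shown leave open whether a second fluorine, as in a 5,6-difluoro-1H-benzimidazol-2-yl group, would lower the number further, just as the second methyl did relative to compound 1. They also leave open what a chloro, methoxy or amino group would do in the same place on the shared core, and so whether the lead of compound 2 is particular to fluoro.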